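Sulfonyl aryl variation on a shared core: compound 4 forecast

A few compounds are considered here, and "the series" means these few. Any claim that something is new, unique, unknown or untested is made for them only; others in the source may bear on it.

Measured so far:
- compound 1 `CNCc1cn(S(=O)(=O)c2ccoc2)c(-c2cccnc2F)c1F`: 95%
- compound 2 `CNCc1cn(S(=O)(=O)c2ccc(OC)cn2)c(-c2cccnc2F)c1F`: 95%
- compound 3 `CNCc1cn(S(=O)(=O)c2cncc(Cl)c2)c(-c2cccnc2F)c1F`: "not determined" (no result reported)

In a functional assay on the whole organism (strain Jcl:Sprague-Dawley) for inhibition, with Rattus norvegicus as the target, with stated times of 3 min and 3 h, at a dose of 1 mg/kg by the intravenous route (on this read-out lower numbers stand for less inhibition and higher numbers for more inhibition at the one dose given (going by the name of the read-out)), compound 1 gives 95% and compound 2 gives 95%. Within the data shown here, the only step between measured compounds that changes the group on the sulfonyl sulfur is no change at the digits printed from compound 1 to compound 2 (within the scatter). Compound 3 gives "not determined" (no result reported) in this assay, so the step to compound 4 `CNCc1cn(S(=O)(=O)c2cccnc2C)c(-c2cccnc2F)c1F` cannot be anchored to a measured starting point. The change is 2-methylpyridin-3-yl in place of 5-chloropyridin-3-yl on a sulfonyl sulfur; it again alters only the group on the sulfonyl sulfur, the same place that was changed from compound 1 to compound 2 without effect beyond the scatter. Among the measured compounds shown here, no other step bears on it. Compound 4 is therefore expected to give about 90% in this assay, within 70% to 99%, with the wider range reflecting that compound 3 itself has no measured value.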

Compound 4, a percentage reported as inhibition, in the whole organism at one dose (the size of the read-out at that dose, not a potency): 92%
For compound 4 the middle estimate is 2 percentage points below the measured one, within the range that was stated.
By their numbers in this assay, from the lowest: compounds 4, 1 and 2 (each within the scatter of the next).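

In this assay, placing 2-methylpyridin-3-yl on the sulfonyl sulfur gives a number 3 percentage points lower from compound 1 to compound 4 (within the scatter) and a number 3 percentage points lower from compound 2 to compound 4 (within the scatter). The flat reading at this position therefore now spans three groups rather than two: furan-3-yl, 5-methoxypyridin-2-yl and 2-methylpyridin-3-yl, the last carrying a methyl group on a pyridine ring. No supporting data bear on the reason for this flat reading.

Still open, from the compounds shown here alone, is whether a non-aromatic group on the sulfonyl sulfur, such as cyclopropyl or a longer alkyl chain, would hold the read-out. With one dose per compound, these values do not rank the compounds by potency.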